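A few compounds are considered here, and "the series" means these few. Any claim that something is new, unique, unknown or untested is made for them only; others in the source may bear on it.

Measured so far in an assay on CHO cells for antagonist activity at transient receptor potential cation channel subfamily V member 1 (Homo sapiens), read by FLIPR; on this read-out lower numbers stand for stronger inhibition and higher numbers for weaker inhibition:
compound 1 `CCCN(CCC)c1cc(C(F)(F)F)ccc1CNC(=O)C(C)c1ccc(NS(C)(=O)=O)c(F)c1` — 0.3 nM
compound 2 `CC(C(=O)NCc1ccc(C(F)(F)F)cc1N1CCC(C(F)(F)F)CC1)c1ccc(NS(C)(=O)=O)c(F)c1` — 0.4 nM

Compound 2 is the second of the two numbers; the nearest is that of compound 1, and the step of a 1.3-fold higher number from compound 1 to compound 2 (0.12 log units; within the scatter) falls within the scatter, so the two cannot be separated on the present data. Within the data shown here, that one step is also the only measured change at the amino substituent on the core, ortho to a large group and meta to a trifluoromethyl group, and it is the only step that bears on compound 3 `CC(C(=O)NCc1ccc(C(F)(F)F)cc1N1CCN(c2ccccc2)CC1)c1ccc(NS(C)(=O)=O)c(F)c1`. Compound 3 differs from compound 2 by 4-phenylpiperazin-1-yl in place of 4-(trifluoromethyl)piperidin-1-yl on an aromatic carbon. Among the measured compounds shown here, no measured compound carries a 4-phenylpiperazin-1-yl group, so the only guide is that the earlier exchange at this position, a 1.3-fold higher number from compound 1 to compound 2 (0.12 log units; within the scatter), left the number essentially unchanged. From the compounds shown here alone, a similar outcome is expected, with a small step of a 1.5-fold higher number from compound 2 to compound 3 (0.18 log units; within the scatter) that should stay near the scatter, and with wider uncertainty since the entering group is untested. The estimate for compound 3 in this assay is 0.6 nM, within a range from 0.15 nM to 3 nM.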

Compound 3, inhibition constant: 2 nM
The estimate for compound 3 lay 3.3-fold (0.52 log units) below the measured number, and the stated range covers the measured number.
By their numbers in this assay, from the lowest: compounds 1 and 2 (each within the scatter of the next); then compound 3.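

In this assay, the amino substituent on the aromatic carbon, ortho to a large group and meta to a trifluoromethyl group, now proves sensitive to exchange: 4-phenylpiperazin-1-yl in place of 4-(trifluoromethyl)piperidin-1-yl gives a 5.0-fold higher number from compound 2 to compound 3 (0.70 log units; beyond the scatter), and 4-phenylpiperazin-1-yl in place of dipropylamino gives a 6.7-fold higher number from compound 1 to compound 3 (0.82 log units; beyond the scatter). Unlike the exchange between dipropylamino and 4-(trifluoromethyl)piperidin-1-yl, which stays within the scatter, both changes to 4-phenylpiperazin-1-yl go beyond it, so this position does not accept every amino group alike, although both steps are modest and compound 3 still reads 2 nM in the same assay. No measurement here accounts for the difference between these groups.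

The exchange changes the ring and adds a phenyl group at once, so the compounds shown cannot say whether the higher number follows the piperazine ring or the phenyl ring. 4-Phenylpiperidin-1-yl and 4-methylpiperazin-1-yl at the same position would separate those two changes, while a plain piperidin-1-yl group would show how much the ring alone contributes without any substituent at its far end.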